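Anilide series: fluoro to tert-butyl on the thioether aryl

The source may report more compounds than this note shows. Statements on the series, on what has been measured and on what is new or still open speak of the compounds shown alone.

Measured compounds, read in a functional assay on A-375 cells (Homo sapiens) for inhibition, read by CCK-8 assay, with a stated time of 72 h, tested at 8 uM; on this read-out lower numbers stand for less inhibition of growth and higher numbers for more inhibition of growth at the one concentration tested:
compound 1 `Nc1ccccc1NC(=O)c1ccc(CSc2ccc(Br)cc2)cc1`; compound 1 gives 6.17%
compound 2 `Nc1ccccc1NC(=O)/C=C/c1ccc(CSc2ccc(F)cc2)cc1`; compound 2 gives 24.6%

Compound 2 stands highest of the two numbers in this assay. Its nearest neighbour, compound 1, sits lower, and the gap between the two values is beyond the usual scatter of this read-out; the two compounds differ in more than one place, so nothing is drawn from that gap about any single change.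

Compound 3 `CC(C)(C)c1ccc(SCc2ccc(/C=C/C(=O)Nc3ccccc3N)cc2)cc1` has not yet been measured. It differs from compound 2 in one place: tert-butyl in place of fluoro on an aromatic carbon. Going by the values given here, no step between measured compounds isolates this change, so the expectation rests on compound 2 alone. The step is expected to be small, a number 3.4 percentage points higher from compound 2 to compound 3 (within the scatter), with no direction claimed beyond the scatter. Compound 3 is therefore estimated at 28% in this assay, within a range from 10% to 50%.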

Compound 3, percent growth inhibition at one concentration: 35.5%
Estimate against measurement, compound 3: 7.5 percentage points below; low and high end bracket the measured number.
By their numbers in this assay, from the lowest: compound 1; then compound 2; then compound 3.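

Tert-butyl in place of fluoro on this aromatic carbon gives a number 10.9 percentage points higher from compound 2 to compound 3 (beyond the scatter) in this assay and is the first change in the series that can be read in one place. The position therefore tolerates tert-butyl, with its four heavy atoms in place of the single fluorine, with no loss of growth inhibition at the one concentration tested, and the number rises modestly. Nothing available bears on why the number rises.

Open, from the compounds shown here alone, is whether the rise follows from the size of the group or is particular to tert-butyl, since one step cannot separate these, and an amine, a methoxy group or a carboxylic acid at this place would test that. Compound 1 and compound 2 differ in more than one place. The gap between them says nothing about any single change.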